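A few compounds are considered here, and "the series" means these few. Any claim that something is new, unique, unknown or untested is made for them only; others in the source may bear on it.

Measured compounds:
Compound 1, `Cc1ccc(S(=O)(=O)N2C/C(=C\c3cccc(F)c3)C(=O)/C(=C/c3cccc(F)c3)C2)cc1`: 3500 nM
Compound 2, `O=C1/C(=C/c2cccc(F)c2)CN(S(=O)(=O)c2ccc(F)cc2)C/C1=C\c1cccc(F)c1`: 5000 nM

Both compounds were tested in a functional assay on HepG2 cells (Homo sapiens) for cytotoxicity, read by MTT assay, with a stated time of 24 h; a higher number here means a weaker inhibitor, a lower number a stronger inhibitor. Compound 1 gives 3500 nM, and compound 2 gives 5000 nM. For the measured compounds named here, the single step between them, a 1.4-fold higher number from compound 1 to compound 2 (0.15 log units; within the scatter), is fluoro in place of methyl on an aromatic carbon and does not reach beyond the scatter. Compound 2 therefore holds the higher of the two numbers, but the two compounds cannot be told apart on this evidence.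

Compound 3, `CC(=O)Nc1ccc(S(=O)(=O)N2C/C(=C\c3cccc(F)c3)C(=O)/C(=C/c3cccc(F)c3)C2)cc1`, has not been measured. It differs from compound 2 by acetamido in place of fluoro on an aromatic carbon. Going by the values given here, no measured step concerns an acetamido group; the only step in hand, from methyl to fluoro, bears on the same aromatic carbon but on a different exchange, and it was flat. With nothing pointing either way, no step beyond the scatter is expected for compound 3 in this assay, with a wide range to allow for the larger, donor-bearing group. The expected step is no change at the digits printed from compound 2 to compound 3 (within the scatter). Compound 3 is thus estimated at 5000 nM, within 1800 nM to 15000 nM.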

Compound 3, half-maximal inhibitory concentration: 11100 nM
Compound 3: middle estimate off by 2.2-fold (0.35 log units), on the low side, and the stated range covers the measured number.
By their numbers in this assay, from the lowest: compounds 1 and 2 (each within the scatter of the next); then compound 3.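

Compared with methyl and fluoro alone, the aromatic carbon para to a large group looked insensitive, but the larger acetamido group shows that this position can shift the reading in this assay. Acetamido in place of fluoro gives a 2.2-fold higher number from compound 2 to compound 3 (0.35 log units; beyond the scatter), and acetamido in place of methyl gives a 3.2-fold higher number from compound 1 to compound 3 (0.50 log units; beyond the scatter). Compound 3 thus stands apart from both earlier compounds as the weakest of the three here, although both steps are modest, and no measurement at hand bears on what lies behind the shift.

From the compounds shown here alone, it remains open whether the shift belongs to the acetamido group in particular or would also appear with an amine, a methoxy group or a longer acyl chain at the same place in this assay. Also open, going by these compounds, is whether the exchange of fluoro for acetamido would give a similar step with other groups elsewhere on the molecule, as all three compounds share the same core and the same pair of 3-fluorophenyl groups.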